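Compound 4: 3,4-dimethylphenyl in place of 4-methoxyphenyl

The compounds below may be only part of what the source reports. "The series", "measured", "known", "first", "only" and "open" are said of these compounds alone.

In a functional assay on C8166 cells (Homo sapiens) for cytotoxicity, read by MTT assay (a higher number here means that more compound is tolerated, a lower number that less compound is tolerated), compound 1 `Cc1cc(S(N)(=O)=O)ccc1NC(=O)COc1ccc(Cl)cc1NC(=O)c1ccccc1[N+](=O)[O-]` gives 54800 nM, compound 2 `Cc1cc(S(N)(=O)=O)ccc1NC(=O)COc1ccc(Cl)cc1NC(=O)c1cccc(C(F)(F)F)c1` gives 124000 nM and compound 3 `COc1ccc(C(=O)Nc2cc(Cl)ccc2OCC(=O)Nc2ccc(S(N)(=O)=O)cc2C)cc1` gives 69500 nM. These compounds differ only in the group on a carbonyl carbon. Compound 3 cannot be told apart from either of the others, with a 1.3-fold higher number from compound 1 to compound 3 (0.10 log units; within the scatter) and a 1.8-fold lower number from compound 2 to compound 3 (0.25 log units; within the scatter). Only a 2.3-fold higher number from compound 1 to compound 2 (0.35 log units; beyond the scatter) clears the scatter, and modestly. Compound 4 `Cc1ccc(C(=O)Nc2cc(Cl)ccc2OCC(=O)Nc2ccc(S(N)(=O)=O)cc2C)cc1C` changes the same place: 3,4-dimethylphenyl in place of 4-methoxyphenyl on a carbonyl carbon. The largest step seen there is small, so no step beyond the scatter is expected in this assay. The estimated change is a 1.1-fold higher number from compound 3 to compound 4 (0.05 log units; within the scatter). Compound 4 is expected at 78000 nM, within an estimated range of 38000 nM to 160000 nM.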

Compound 4, half-maximal cytotoxic concentration: 84100 nM
The estimate for compound 4 lay 1.1-fold (0.03 log units) below the measured number; the range from low to high includes it.
By their numbers in this assay, from the lowest: compounds 1, 3, 4 and 2 (each within the scatter of the next, the first and the last beyond it).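

In this assay, a phenyl ring carrying no hydrogen-bond acceptor cannot be told apart from one carrying an acceptor in its methoxy group, with a 1.2-fold higher number from compound 3 to compound 4 (0.08 log units; within the scatter). The 3,4-dimethylphenyl group also stays within the scatter of the two other groups, with a 1.5-fold lower number from compound 2 to compound 4 (0.17 log units; within the scatter) and a 1.5-fold higher number from compound 1 to compound 4 (0.19 log units; within the scatter). No evidence is available to explain these numbers. From the compounds shown here alone, what stays open is whether a ring bearing an amine or a carboxylic acid, or a longer chain in place of the ring, would move the number beyond the scatter.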